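Hydroxy for Fluoro on the Anilide of Compound 1

The compounds below may be only part of what the source reports. "The series", "measured", "known", "first", "only" and "open" are said of these compounds alone.

Measured compounds:
compound 1, `CN(C)C(=O)c1cc2cnc(Nc3ccc(NC(=O)C4(C(=O)Nc5ccc(F)cc5)CC4)cc3)nc2n1C1CCCC1`, 79.9%
compound 2, `CN(C)C(=O)c1cc2cnc(Nc3ccc(NC(=O)C4(C(=O)Nc5cccc(F)c5)CC4)cc3)nc2n1C1CCCC1`, 45.1%

In a functional assay on NCI-H460 cells (Homo sapiens) for inhibition, read by CCK-8 assay, with a stated time of 72 h, tested at 1 uM (on this read-out higher numbers stand for more inhibition of growth at the one concentration tested and lower numbers for less inhibition of growth), compound 1 gives 79.9%, the higher of the two numbers measured. Compound 2 gives 45.1% in this assay. Among the compounds with values here, the one step measured, 3-fluorophenyl in place of 4-fluorophenyl on an amide-type nitrogen, is a number 34.8 percentage points lower from compound 1 to compound 2 (beyond the scatter), so this assay responds strongly to what sits on that phenyl ring.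

Compound 3, `CN(C)C(=O)c1cc2cnc(Nc3ccc(NC(=O)C4(C(=O)Nc5ccc(O)cc5)CC4)cc3)nc2n1C1CCCC1`, is not yet measured. It differs from compound 1 by hydroxy in place of fluoro on an aromatic carbon. Within the data shown here, no measured step swaps one group for another at that aromatic carbon; the step from compound 1 to compound 2 only shows that the ring is sensitive to change and bears on compound 3 indirectly. The direction therefore cannot be read from the data, but a step of some size, most likely downward, is expected. For compound 3 an estimated value of 60% is expected, within 30% to 85%, meaning an expected step of a number 19.9 percentage points lower from compound 1 to compound 3 (beyond the scatter).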

Compound 3, percent growth inhibition at one concentration: 90.4%
Estimate against measurement, compound 3: 30.4 percentage points below; the whole stated range lies below it.
By their numbers in this assay, from the lowest: compound 2; then compound 1; then compound 3.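

Within the data shown here, compound 1 had been the top of the series, and the only earlier step showed what happens when fluoro leaves this carbon for another place on the ring. Keeping the place and changing the group instead gives, in this assay, a number 10.5 percentage points higher from compound 1 to compound 3 (beyond the scatter), so fluoro is not required on this aromatic carbon, and hydroxy, which adds a hydrogen-bond donor and a hydrogen-bond acceptor by count, is accepted there with a modest gain. Set against the other fluoro compound, 4-hydroxyphenyl in place of 3-fluorophenyl gives a number 45.3 percentage points higher from compound 2 to compound 3 (beyond the scatter), which leaves compound 3 with the highest number of the three; nothing shown accounts for the gain with hydroxy.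

The compounds shown leave open whether other groups on this carbon, such as an amine or a methoxy, would hold the number, and whether hydroxy would lose as much as fluoro does when placed as in compound 2. They also leave open whether the order holds at other concentrations or in other cell lines, since all three numbers come from a single concentration in one cell line.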